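Fluoro to methyl on the core of compound 2

The source may hold more compounds than are shown below. What is called first, only, known or untested is meant among the compounds shown, and "the series" means these compounds.

Working notes on the series. Compound 1 `C[C@H]1O[C@@H](n2ccc(=O)[nH]c2=O)C=C(F)C1=O` gives 2900 nM in a functional assay on L1210 cells (Mus musculus) for cytotoxicity; a higher number here means a weaker inhibitor, a lower number a stronger inhibitor. Within the data shown here, compound 2 `C[C@H]1O[C@@H](n2cc(F)c(=O)[nH]c2=O)C=C(F)C1=O` gives 820 nM in the same assay, the lowest of the two numbers so far; the step of a 3.5-fold lower number from compound 1 to compound 2 (0.55 log units; beyond the scatter) is the only step measured between compounds differing in one place. Compound 3 `Cc1cn([C@H]2C=C(F)C(=O)[C@@H](C)O2)c(=O)[nH]c1=O` is not yet measured; it differs from compound 2 by methyl in place of fluoro on an aromatic carbon, the change sitting on an aromatic carbon of the six-membered aromatic ring with two nitrogens, two atoms from the ring nitrogen. Among the measured compounds shown here, no measured step exchanges fluoro for methyl, so the bearing of the single step is indirect: it shows that this position moves the number beyond the scatter when hydrogen is replaced by fluoro, but says nothing about methyl. Compound 3 is therefore estimated at 1500 nM, within 500 nM to 5000 nM, the expected step being a 1.8-fold higher number from compound 2 to compound 3 (0.26 log units; within the scatter).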

Compound 3, half-maximal inhibitory concentration: 2800 nM
For compound 3 the middle estimate is 1.9-fold (0.27 log units) below the measured one, and the stated range covers the measured number.
By their numbers in this assay, from the lowest: compound 2; then compounds 3 and 1 (each within the scatter of the next).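

In this assay, methyl in place of fluoro on this aromatic carbon, two atoms from the ring nitrogen, gives a 3.4-fold higher number from compound 2 to compound 3 (0.53 log units; beyond the scatter) and so does not keep the lower number seen with fluoro. Set against hydrogen at the same carbon, methyl gives a 1.0-fold lower number from compound 1 to compound 3 (0.02 log units; within the scatter), which leaves the two indistinguishable here and shows that filling this position does not by itself lower the number: among the three groups, only fluoro stands apart. Nothing available gives a reason for the difference between fluoro and methyl at this carbon.

Still open, as far as these compounds go, is how chloro, an amine or a longer chain such as ethyl would read on this carbon. Among these compounds, also open is whether the same pattern among hydrogen, fluoro and methyl holds on any core other than the one shared by these compounds.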